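This account rests on a few compounds, and the source may have more. Where it says the series, first, only, none or still open, it means among the compounds named here.

In a functional assay on NCI-H522 cells (Homo sapiens) for cytotoxicity, with a stated time of 3 days (a lower number here means a stronger inhibitor, a higher number a weaker inhibitor), compound 1 `C#Cc1nc(C(=O)N2CCN(CC)CC2)cs1` stands at > 1000 nM, which is a limit and not a number. Compound 2 `Ic1nc2ccccc2s1` gives > 40000 nM, also a limit. Compound 3 `C#Cc1nc(C(=O)Nc2ccccc2)cs1` gives a measured 660 nM. Compound 4 `C#Cc1nc(C(=O)N2CCN(c3ccc(F)cc3)CC2)cs1` keeps the core of compound 1 and has 4-fluorophenyl in place of ethyl on an amine nitrogen in a ring. Within the data shown here, no measured step covers this change, so the expectation rests on little. Compound 3, at 660 nM, also carries a six-membered aromatic ring of carbon only, and on that ground a gain beyond the scatter in this assay is expected. The expected step is an at least 1.4-fold lower number from compound 1 to compound 4 (0.15 log units; that floor lies within the scatter). For compound 4 the estimated value is 700 nM, with a range of 200 nM to 3000 nM.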

Compound 4, half-maximal inhibitory concentration: 64 nM
For compound 4 the middle estimate is 11-fold (1.04 log units) above the measured one, and the stated range ends above it.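

In this assay, among these compounds, 4-fluorophenyl in place of ethyl on the amine nitrogen in the ring gives an at least 15-fold lower number from compound 1 to compound 4 (1.19 log units; beyond the scatter), so this position, which no earlier step covered, responds strongly to the group it carries. That size is only a floor, because compound 1 stands at a limit: the limit of > 1000 nM in this assay, at which 1 of the 4 values shown sits.

The compounds shown leave open whether the fluorine or the six-membered aromatic ring of carbon accounts for the step, which a plain phenyl group would help to separate. From the compounds shown here alone, how a benzyl group or a longer alkyl chain would fare at this nitrogen also remains open.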